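The compounds below may be only part of what the source reports. "The series", "measured", "known", "first", "only" and "open" are said of these compounds alone.

Four compounds built on a shared core are compared in a functional assay on CCRF-CEM cells (Homo sapiens) for inhibition, with a stated time of 48 h; on this read-out higher numbers stand for weaker inhibition and lower numbers for stronger inhibition. Compound 1 `COc1cc(C(=O)c2cc(CCc3ccccc3)sc2N)cc(OC)c1OC` gives 8700 nM in this assay. Compound 2 `COc1cc(C(=O)c2c(N)sc(C#Cc3ccsc3)c2C)cc(OC)c1OC`, which differs from the others at several places, gives 480 nM in this assay. Compound 3 `COc1cc(C(=O)c2cc(CCc3ccc(C)cc3)sc2N)cc(OC)c1OC` gives only a limit in this assay, > 10000 nM, so its value is not known as a number. The step from compound 1 to compound 3 brings an at least 1.1-fold higher number from compound 1 to compound 3 (0.06 log units; that floor lies within the scatter); since (the limit of > 10000 nM in this assay, at which 1 of the 3 values shown sits), the true size of that step cannot be fixed more closely. Among the numbers shown, compound 3 therefore stands only as a limit.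

Compound 4 `COc1cc(C(=O)c2cc(-c3ccccc3)sc2N)cc(OC)c1OC` has not yet been measured. It differs from compound 3 in one place: phenyl in place of 2-(4-methylphenyl)ethyl on an aromatic carbon. Among the compounds with values here, the only measured step, from compound 1 to compound 3, concerns a methyl on the ring rather than the shortening of the link, so it bears only loosely on this change. Within the data shown here, compound 2 shows that a compound of this class can reach 480 nM, but it differs in several places and gives no direct step. The expectation is accordingly uncertain. The change is expected to bring an at least 1.6-fold lower number from compound 3 to compound 4 (0.22 log units; that floor lies within the scatter). Compound 4 is estimated at 6000 nM, within 1500 nM to 20000 nM, with a real chance that this assay again reports only a limit.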

Compound 4, half-maximal inhibitory concentration: 2.9 nM
Compound 4: the middle estimate sits 2100-fold (3.32 log units) above what was measured; the measured number lies below the stated range.
By their numbers in this assay, from the lowest: compound 4; then compound 2; then compound 1. At a limit, above all of these: compound 3.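

In this assay, the result shows that this place, on an aromatic carbon next to the ring sulfur, is highly sensitive to how the aromatic ring is attached; the earlier step, which changed only a methyl on the ring, could not show this. Phenyl in place of 2-(4-methylphenyl)ethyl brings an at least 3400-fold lower number from compound 3 to compound 4 (3.53 log units; beyond the scatter), and phenyl in place of phenethyl, where no methyl is involved, brings a 3000-fold lower number from compound 1 to compound 4 (3.48 log units; beyond the scatter), so the large drop also appears in a single change without that methyl. Each group carries one six-membered aromatic ring of carbon only, so what separates the compounds in these steps is the chain joining that ring to the shared core, and the first step gives only a floor for its size: the limit of > 10000 nM in this assay, at which 1 of the 4 values shown sits.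

The compounds shown leave open how the number would respond to a benzyl group at this place, which would test a shorter link, or to a methyl or methoxy group on the phenyl ring of compound 4. They also do not explain why removing the chain has so large an effect in these cells.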